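The source may report more compounds than this note shows. Statements on the series, on what has been measured and on what is new or still open speak of the compounds shown alone.

Measured so far in an ADME assay on MDCK cells (Canis lupus familiaris) for cytotoxicity; a higher number here means that more compound is tolerated, a lower number that less compound is tolerated:

- Compound 1 `CC(=O)Nc1ccc2oc(-c3ccnc(C(=O)N4CCC5(CC4)CN(C(c4ccccc4)c4nnn(C)n4)C5)c3)nc2c1`: > 50000 nM
- Compound 2 `CC(=O)Nc1ccc2oc(-c3ccnc(C(=O)N4CCN(C(c5nnn(C)n5)c5ccccc5F)CC4)c3)nc2c1`: > 50000 nM
- Compound 3 `CC(=O)Nc1ccc2oc(-c3ccnc(C(=O)N4CCN(C(c5ccc(OC(F)(F)F)cc5)c5nnn(C)n5)CC4)c3)nc2c1`: > 50000 nM

Each of these entries is a limit of the assay and not a number. Compound 2 therefore has no exact position on the scale, and its entry of > 50000 nM is only a limit. The picture across the set is uniform: the limit of > 50000 nM in this assay, at which 3 of the 3 values shown sit.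

Compound 4 `CC(=O)Nc1ccc2oc(-c3ccnc(C(=O)N4CCN(C(c5ccc(C)cc5)c5nnn(C)n5)CC4)c3)nc2c1` differs from compound 2 in one place: 4-methylphenyl in place of 2-fluorophenyl on a saturated chain carbon bound to an amine nitrogen in a ring and an aromatic carbon. Here, 4-methylphenyl stands in place of 2-fluorophenyl on a saturated chain carbon bound to an amine nitrogen in a ring and an aromatic carbon.

The measured change that bears on this is a step that the two limits leave unreadable from compound 2 to compound 3, with 4-(trifluoromethoxy)phenyl entering in the same place. Its size gives no number to carry over, but compound 3 still stands at the limit of > 50000 nM. No step beyond the scatter is expected in this assay, and no direction can be given. The expected outcome is a number no higher from compound 2 to compound 4 (the limit leaves the size open). Compound 4 is estimated at 50000 nM, with an expected range of 30000 nM to 100000 nM, and will most likely be reported only as a limit.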

Compound 4, half-maximal cytotoxic concentration: > 50000 nM
Compound 4: only a limit was reported (the forecaster's own chance of this, stated with the estimate: 85%); the middle value sits exactly at the limit.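

Compound 4 gives > 50000 nM, which is a limit of the assay and not a number. The steps from compound 2 and from compound 3 to compound 4 therefore cannot be read. The compounds shown leave open where any of them truly stands on the scale, as all share one result: the limit of > 50000 nM in this assay, at which 4 of the 4 values shown sit.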